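This account rests on a few compounds, and the source may have more. Where it says the series, first, only, none or still open, it means among the compounds named here.

Working notes on the series built on the shared core of compound 1 `CCCSc1nc(N/N=C/c2cccnc2)c2nnn(Cc3ccccc3)c2n1`. In a functional assay on ECa-109 cells (Homo sapiens) for antiproliferative activity, read by MTT assay, with a stated time of 72 h (a higher number here means a weaker inhibitor, a lower number a stronger inhibitor), compound 1 gives > 64000 nM, which is a limit of the assay and not a number. Compound 2 `CCCSc1nc(N/N=C/c2ccc(Br)cc2)c2nnn(Cc3ccccc3)c2n1` in this assay gives > 64000 nM, likewise only a limit. Compound 3 `CCCSc1nc(N/N=C/c2ccccc2F)c2nnn(Cc3ccccc3)c2n1` in this assay gives > 64000 nM, again a limit rather than a number. The steps a step that the two limits leave unreadable from compound 1 to compound 2, a step that the two limits leave unreadable from compound 1 to compound 3 and a step that the two limits leave unreadable from compound 2 to compound 3 cannot be read because of the limit of > 64000 nM in this assay, at which 3 of the 3 values shown sit. Compound 4 `CCCSc1nc(N/N=C/c2ccc([N+](=O)[O-])cc2)c2nnn(Cc3ccccc3)c2n1` differs from compound 3 by 4-nitrophenyl in place of 2-fluorophenyl on a carbon with a double bond to nitrogen. Among the compounds with values here, none of the measured steps gives a readable size for this kind of change, so no direction is indicated by the series, and a further limit is the most likely outcome. Compound 4 is expected to give 80000 nM, with a range from 30000 nM to 300000 nM, an estimated step that the limit leaves unreadable from compound 3 to compound 4.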

Compound 4, half-maximal inhibitory concentration: 6640 nM
Compound 4: middle estimate off by 12-fold (1.08 log units), on the high side, and the stated range ends above it.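

In this assay, within the data shown here, 4-nitrophenyl on a carbon with a double bond to nitrogen gives the first readable steps: an at least 9.6-fold lower number from compound 3 to compound 4 (0.98 log units; beyond the scatter) and an at least 9.6-fold lower number from compound 2 to compound 4 (0.98 log units; beyond the scatter) and an at least 9.6-fold lower number from compound 1 to compound 4 (0.98 log units; beyond the scatter). The group at this place can therefore bring the read-out off the limit, which 2-fluorophenyl, 4-bromophenyl and pyridin-3-yl do not do. Each step gives only a lower bound on its size, set by the limit of compounds 1 to 3: the limit of > 64000 nM in this assay, at which 3 of the 4 values shown sit.

Whether the nitro group alone accounts for the change stays open. So does whether a nitrile or an amine in place of nitro would also give a readable value.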